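This account rests on a few compounds, and the source may have more. Where it says the series, first, only, none or still open, it means among the compounds named here.

Compound 1 `CCOC(=O)/C=C/NC(=O)[C@H](O)C(C)(C)CO` is the reference point of this set. Among the measured compounds shown here, in an ADME assay on WI-38 cells (Homo sapiens) for inhibition, read by CellTiter-Glo, with a stated time of 48 h, tested at 100 uM (on this read-out higher numbers stand for more inhibition at the one concentration tested (going by the name of the read-out) and lower numbers for less inhibition), compound 1 gives 36%, the highest of the three numbers measured so far. Compound 2 `CC(C)(C)OC(=O)/C=C/NC(=O)[C@H](O)C(C)(C)CO` gives 0%, and compound 3 `CC(C)(CO)[C@H](O)C(=O)N/C=C\C(=O)OCc1ccccc1` gives -2%; both gaps from compound 1 lie beyond the scatter. For the measured compounds named here, the only single-point step measured is a number 36 percentage points lower from compound 1 to compound 2 (beyond the scatter). Compound 3 differs from compound 1 in more than one place, so its gap to compound 1 is taken only as the two values show it.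

Compound 4 `CCOC(=O)/C=C/NC(=O)[C@@H](O)C(C)(C)CO` is not yet measured. Against compound 1 the change is the two compounds have the same atoms and bonds and differ only in configuration as drawn: 1 of 2 stereo elements differ; a stereocentre at a saturated chain carbon is drawn R in compound 1 and S in compound 4. Going by the values given here, no measured step in this set touches a stereocentre: the step from compound 1 to compound 2 alters the ester, and the remaining pair changes both the ester and the double-bond configuration. There is therefore no direct guide for the size of the step in this assay. A change of configuration alone is expected to move the read-out less than the ester change did, with no clear direction from these data. Compound 4 is estimated at 30%, with a range of 10% to 50%. The step so expected is a number 6 percentage points lower from compound 1 to compound 4 (within the scatter).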

Compound 4, a percentage reported as inhibition, at one concentration (the size of the read-out at that concentration, not a potency): -6%
The estimate for compound 4 lay 36 percentage points above the measured number; measured number below the stated range.
By their numbers in this assay, from the lowest: compounds 4, 3 and 2 (each within the scatter of the next); then compound 1.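

In this assay, the stereocentre at the saturated chain carbon proves to be a sensitive position: going from R to S gives a number 42 percentage points lower from compound 1 to compound 4 (beyond the scatter). Until now only the ester had been shown to carry a large single-point step, whereas here the atoms and bonds stay the same and only one of the two stereo elements changes. The step can be assigned to the configuration at this carbon because nothing else separates the pair: the fact that compounds 1 and 4 differ only in the configuration as drawn

The compounds shown leave open whether the R configuration is needed with other esters, since the S form is shown only with the ethyl ester, and whether the step of a number 36 percentage points lower from compound 1 to compound 2 (beyond the scatter) and the step at the stereocentre act independently of each other. They also leave open whether a carboxylic acid or a primary amide in place of the ethyl ester, or a longer chain such as n-propyl on the ester oxygen, would keep the read-out of compound 1 at 36% in this assay.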